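The source may report more compounds than this note shows. Statements on the series, on what has been measured and on what is new or still open speak of the compounds shown alone.

Measured compounds and their numbers:

Compound 1 `Cc1ccc2occ(C3N=C(c4ccccc4)SS3)c(=O)c2c1`: 67%
Compound 2 `O=c1c(C2N=C(c3ccccc3)SS2)coc2ccc(Cl)cc12`: 73%
Compound 3 `O=c1c(C2N=C(c3ccccc3)SS2)coc2cc(Cl)ccc12`: 76%

All three share one core and were tested in a functional assay on A549 cells (Homo sapiens) for inhibition, read by sulforhodamine B assay, with a stated time of 48 h, tested at 100 uM; on this read-out lower numbers stand for less inhibition of growth and higher numbers for more inhibition of growth at the one concentration tested. For the measured compounds named here, compound 3 gives 76%, and the numbers of compound 2 and compound 1 lie so close to it that all three fall within the usual scatter of one another; no compound can be singled out as stronger or weaker on this evidence.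

The next compound, compound 4 `O=c1c(C2N=C(c3ccccc3)SS2)coc2ccccc12`, differs from compound 3 in one place: hydrogen in place of chloro on an aromatic carbon. Among the measured pairs, only one step touches this part of the molecule, the exchange from compound 1 to compound 2, which gave a number 6 percentage points higher from compound 1 to compound 2 (within the scatter). That step swapped one small group for another on the aromatic carbon, whereas the move to compound 4 takes the chloro away and leaves only hydrogen. Going by the values given here, no measured pair shows what a bare carbon at this place does, so the expectation rests on the observation that changing the group there moved this assay only within the scatter.

Compound 4 is therefore expected to give an estimated 68%, with a range from 52% to 84%. This estimate means a step of a number 8 percentage points lower from compound 3 to compound 4 (within the scatter), which is not expected to exceed the scatter.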

Compound 4, percent growth inhibition at one concentration: 42%
Estimate against measurement, compound 4: 26 percentage points above, outside the stated range (below it).
By their numbers in this assay, from the lowest: compound 4; then compounds 1, 2 and 3 (each within the scatter of the next).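

Earlier, methyl and chloro could be exchanged on the aromatic carbon within the scatter in this assay, which left open whether a group there mattered at all; the bare carbon now shows that it does. Compound 2 and compound 3 carry their chloro on different aromatic carbons, yet hydrogen in its place gives a number 34 percentage points lower from compound 3 to compound 4 (beyond the scatter) and a number 31 percentage points lower from compound 2 to compound 4 (beyond the scatter), both large steps, while hydrogen in place of methyl gives a number 25 percentage points lower from compound 1 to compound 4 (beyond the scatter), a modest one. Among these four compounds, then, having a methyl or chloro on this ring goes with more inhibition of growth than having hydrogen, with no compound going against that pattern, and nothing shown here gives a reason for it.

As far as these compounds go, it remains open whether a quite different group on this carbon, such as an amine or a methoxy, would keep the level of the chloro compounds or fall to that of the unsubstituted compound 4. From the compounds shown here alone, with a single concentration behind each number, it is also open whether the same gap would appear at other concentrations.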